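From compound 2 to compound 3: another aromatic nitrogen substituent

A few compounds are considered here, and "the series" means these few. Any claim that something is new, unique, unknown or untested is made for them only; others in the source may bear on it.

Compound 1 `CC1(C)CCc2c(ccc(C(=O)/C=C/c3ccc(OCc4cn(-c5ccc(Br)cc5)nn4)cc3)c2O)O1`: 136000 nM
Compound 2 `Cc1c(-n2cc(COc3ccc(/C=C/C(=O)c4ccc5c(c4O)CCC(C)(C)O5)cc3)nn2)cccc1[N+](=O)[O-]`: 115000 nM

In a functional assay on HepG2 cells (Homo sapiens) for antiproliferative activity, read by MTT assay (on this read-out higher numbers stand for weaker inhibition and lower numbers for stronger inhibition), compound 2 gives 115000 nM, which lies within the scatter of compound 1 at 136000 nM. Compound 2 therefore cannot be separated from compound 1 on these numbers, and neither can be ranked above the other.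

The next compound is compound 3 `CC(=O)c1ccc(-n2cc(COc3ccc(/C=C/C(=O)c4ccc5c(c4O)CCC(C)(C)O5)cc3)nn2)cc1`, which carries 4-acetylphenyl in place of 2-methyl-3-nitrophenyl on an aromatic nitrogen. Among the measured compounds shown here, only one measured step bears on this change. It is also an exchange of groups on that aromatic nitrogen, 2-methyl-3-nitrophenyl in place of 4-bromophenyl, and it amounts to a 1.2-fold lower number from compound 1 to compound 2 (0.07 log units; within the scatter). With so little evidence, and with that single exchange leaving the number within the scatter, no step beyond the scatter is expected in this assay, and no direction can be argued from the data. The expected step is a 1.0-fold higher number from compound 2 to compound 3 (0.02 log units; within the scatter).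

Compound 3 is estimated at 120000 nM, with an expected range from 55000 nM to 230000 nM.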

Compound 3, half-maximal inhibitory concentration: 91400 nM
Estimate against measurement, compound 3: 1.3-fold (0.12 log units) above; the measured number falls inside the stated range.
By their numbers in this assay, from the lowest: compounds 3, 2 and 1 (each within the scatter of the next).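

In this assay, 4-acetylphenyl in place of 2-methyl-3-nitrophenyl on the aromatic nitrogen gives a 1.3-fold lower number from compound 2 to compound 3 (0.10 log units; within the scatter) and acetyl in place of bromo on an aromatic carbon of that aryl group gives a 1.5-fold lower number from compound 1 to compound 3 (0.17 log units; within the scatter). Three aryl groups on this nitrogen now lie within the scatter of one another, and this includes a direct exchange of bromo for acetyl on the same aryl group, a comparison the earlier pair of compounds could not offer; on these three compounds, neither that exchange nor the wider exchange of the whole aryl group separates the numbers. No independent measurement is available to account for these results.

As far as these compounds go, all three compounds keep a phenyl ring on this nitrogen, so it remains open whether a carboxylic acid or an amine on that ring, or a cyclohexyl group or a plain alkyl chain in place of the ring, would give a step beyond the scatter. From the compounds shown here alone, it also remains open whether changes elsewhere on the shared core would move the number further than any exchange seen at this position.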